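Iodo on the phenyl ester of compound 3

The source may hold more compounds than are shown below. What is called first, only, known or untested is meant among the compounds shown, and "the series" means these compounds.

Among the measured compounds shown here, compound 3 `NCc1ccc2oc(=O)c(C(=O)Oc3ccccc3)cc2c1` gives 85.5% in a functional assay on HT-1080 cells (Homo sapiens), read by transwell migration, with a stated time of 24 h, tested at 1 uM (a lower number here means a stronger effect, a higher number a weaker effect of the compound at the concentration tested), the highest of the three numbers measured so far; compound 2 `O=C(Oc1ccccc1)c1cc2cc([N+](=O)[O-])ccc2oc1=O` gives 76.7%, within the scatter of compound 3, while compound 1 `CC(C)C(=O)OCc1ccc2oc(=O)c(C(=O)Oc3cccc(Br)c3)cc2c1` gives 37.8%, a gap beyond the scatter. For the measured compounds named here, the single measured step, a number 8.8 percentage points higher from compound 2 to compound 3 (within the scatter), concerns another part of the shared core. Compound 4 `NCc1ccc2oc(=O)c(C(=O)Oc3cccc(I)c3)cc2c1` differs from compound 3 by iodo in place of hydrogen on an aromatic carbon. Going by the values given here, no measured step touches the phenyl ester; compound 1 carries a bromo on that ring but also differs from compound 3 in a second place, so its lower number cannot be assigned to the halogen alone. A lower number is expected for compound 4, a number 20.5 percentage points lower from compound 3 to compound 4 (beyond the scatter), though the step may stay within the scatter. Compound 4 is estimated at 65%, between 35% and 92%.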

Compound 4, a percentage reported as activity, at one concentration (the size of the read-out at that concentration, not a potency): 25.3%
Compound 4: middle estimate off by 39.7 percentage points, on the high side, and the stated range ends above it.
By their numbers in this assay, from the lowest: compound 4; then compound 1; then compounds 2 and 3 (each within the scatter of the next).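

In this assay, among the compounds shown here, going from phenyl to 3-iodophenyl gives a number 60.2 percentage points lower from compound 3 to compound 4 (beyond the scatter), so a single iodo on this ring moves the read-out by a large margin, whereas the only earlier step, a number 8.8 percentage points higher from compound 2 to compound 3 (within the scatter), concerned another part of the shared core. For the compounds shown here, this is the first direct reading of a change on the phenyl ester, free of any second difference. No data at hand account for the size of this step.

The compounds shown leave open whether chloro or methoxy in place of iodo, with the aminomethyl kept, would give a similar number. Also open, going by these compounds, is whether the step holds with a carboxylic acid in place of the aminomethyl.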